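This account rests on a few compounds, and the source may have more. Where it says the series, first, only, none or still open, it means among the compounds named here.

Working notes on the series.

Compound 1 `C=C1CC[C@@H]2[C@](C)(CO)[C@H](O)CC[C@@]2(C)[C@@H]1C/C=C1\C=COC1=O` is one of two members measured in a physicochemical assay for lipophilicity; a lower number here means a more polar compound, a higher number a more lipophilic compound. In this assay compound 1 gives 3.28, the lower of the two numbers available. The other measured member is compound 2 `C=C1CC[C@@H]2[C@](C)(COC(C)=O)[C@H](OC(C)=O)CC[C@@]2(C)[C@@H]1/C=C/C1=CCOC1=O`, which in this assay gives 3.83, a number that lies higher than that of compound 1 by a margin beyond the usual scatter. Compounds 1 and 2 differ in more than one place, so no single step can be read from their two values.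

The open question concerns compound 3 `C=C1CC[C@@H]2[C@](C)(CO)[C@H](O)CC[C@@]2(C)[C@@H]1CCC1=CCOC1=O`, which has not been measured. Relative to compound 1 it shows the following change: a group of 7 heavy atoms (5 carbon, 2 oxygen; one five-membered non-aromatic ring with 1 hetero atom) in place of a group of 7 heavy atoms (5 carbon, 2 oxygen; one five-membered non-aromatic ring with 1 hetero atom), on a saturated chain carbon bound to a saturated ring carbon The replacement keeps the five-membered ring with one hetero atom and both acceptors, and reduces the count of double bonds outside aromatic rings from three to two.

Among the measured compounds shown here, with no step of this kind among the measured pairs, the expectation rests on compound 1 alone. A small upward step, near the edge of the scatter, is expected from compound 1 to compound 3, a number 0.17 log units higher from compound 1 to compound 3 (within the scatter). Compound 3 is accordingly estimated at 3.45 in this assay, with a range from 3 to 3.9.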

Compound 3, partition coefficient: 3.43
Compound 3: the middle estimate sits 0.02 log units above what was measured, and the stated range covers the measured number.
By their numbers in this assay, from the lowest: compounds 1 and 3 (each within the scatter of the next); then compound 2.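

Working from the saturated chain carbon bound to a saturated ring carbon, this is the first comparison in the series that isolates a single place: in this assay, replacing the group with 3 double bonds outside aromatic rings by the group with 2 gives a number 0.15 log units higher from compound 1 to compound 3 (within the scatter). On the core of compound 1, then, this change leaves the read-out within the scatter, with the five-membered non-aromatic ring with 1 hetero atom and the counts of hydrogen-bond donors and acceptors in the group all unchanged, something the pair of compound 1 and compound 2 could not show, since those two differ in more than one place. No available evidence bears on this result, so the step stands as an observation only.

One step at one place does not show whether the same exchange would behave alike on a core carrying the acetyl esters of compound 2. Also open, on these data alone, is what this assay would give with a carboxylic acid, an amine or a longer chain at this saturated chain carbon in place of the ring-bearing group.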